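The source may report more compounds than this note shows. Statements on the series, on what has been measured and on what is new or still open speak of the compounds shown alone.

Three compounds share one core and differ only in what sits on the aromatic ring. Compound 1 `O=C(O)/C=C/C(=O)c1ccc(Cl)c(Cl)c1` carries two chloro groups; in a functional assay on HeLa cells (Homo sapiens) for inhibition, read by MTT assay, with a stated time of 72 h (on this read-out higher numbers stand for weaker inhibition and lower numbers for stronger inhibition), compound 1 gives 28300 nM. Compound 2 `CCc1ccc(C(=O)/C=C/C(=O)O)cc1` carries an ethyl group, and in this assay compound 2 gives 27800 nM. Compound 3 `O=C(O)/C=C/C(=O)c1ccc(F)cc1` carries a fluoro group, and in this assay compound 3 gives 28400 nM. For the measured compounds named here, the only single-point step among them, a 1.0-fold higher number from compound 2 to compound 3 (0.01 log units; within the scatter), lies within the scatter, and the value of compound 3 likewise cannot be told apart from that of compound 1. Compound 4 `O=C(O)/C=C/C(=O)c1ccc(Cl)cc1` is reached from compound 3 by one change: chloro in place of fluoro on an aromatic carbon. Going by the values given here, no measured step covers chloro in place of fluoro on an aromatic carbon directly, but the step from ethyl to fluoro was a 1.0-fold higher number from compound 2 to compound 3 (0.01 log units; within the scatter), and compound 1, which bears chloro, gives a value that sits with the others. Compound 4 is therefore expected to show a step of a 1.0-fold lower number from compound 3 to compound 4 (0.01 log units; within the scatter), nothing beyond the scatter. The estimate for compound 4 in this assay is 28000 nM, with a range from 14000 nM to 56000 nM.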

Compound 4, half-maximal inhibitory concentration: 25400 nM
The estimate for compound 4 lay 1.1-fold (0.04 log units) above the measured number; the range from low to high includes it.
By their numbers in this assay, from the lowest: compounds 4, 2, 1 and 3 (each within the scatter of the next).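

In this assay, chloro in place of fluoro at this place, para to a group of 7 heavy atoms, gives a 1.1-fold lower number from compound 3 to compound 4 (0.05 log units; within the scatter), and chloro in place of ethyl gives a 1.1-fold lower number from compound 2 to compound 4 (0.04 log units; within the scatter), so fluoro, chloro and ethyl at this place cannot be told apart. The other ring position carrying chloro in compound 1 also shows no readable change, with hydrogen in place of chloro giving a 1.1-fold lower number from compound 1 to compound 4 (0.05 log units; within the scatter). No evidence at hand speaks to why these compounds give such similar numbers.

From the compounds shown here alone, whether an amine, a methoxy group or a longer chain at this place would move the number beyond the scatter stays open. So does what hydrogen at this place would give. Going by these compounds, what an amide in place of the carboxylic acid of the shared core would give also stays open.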